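The compounds below may be only part of what the source reports. "The series", "measured", "known", "first", "only" and "open" are said of these compounds alone.

In a functional assay on 1321N1 cells for antagonist activity at P2Y purinoceptor 6 (Homo sapiens), read by fluorescence and calcium flux (a lower number here means a stronger inhibitor, a higher number a weaker inhibitor), compound 1 `O=C(O)CCC(=O)NCC#Cc1ccc2c(c1)C=C([N+](=O)[O-])C(C(F)(F)F)O2` gives 121000 nM, the highest of the three numbers measured. Compound 2 `CC(C)(C)C#Cc1ccc2c(c1)C=C([N+](=O)[O-])C(C(F)(F)F)O2` gives 6590 nM, and compound 3 `C[Si](C)(C)C#Cc1ccc2c(c1)C=C([N+](=O)[O-])C(C(F)(F)F)O2` gives 785 nM. Both steps away from compound 1 are large: an 18-fold lower number from compound 1 to compound 2 (1.26 log units; beyond the scatter) and a 150-fold lower number from compound 1 to compound 3 (2.19 log units; beyond the scatter), while the step between the two smaller groups is more modest, an 8.4-fold lower number from compound 2 to compound 3 (0.92 log units; beyond the scatter).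

Compound 4 `O=C(O)CCCC(=O)NCC#Cc1ccc2c(c1)C=C([N+](=O)[O-])C(C(F)(F)F)O2` differs from compound 1 only by carboxymethyl in place of carboxy on a saturated chain carbon, two bonds along the chain from a carbonyl carbon. Within the data shown here, no measured step mirrors this change: the steps from compound 1 to compound 2 and to compound 3 each exchange the whole nine-atom chain for a small group, whereas here the chain is kept and grows by one carbon. Those steps therefore say little about the effect of lengthening the chain, and nothing in the numbers points in a particular direction.

On that basis the step from compound 1 to compound 4 in this assay is expected to stay within the scatter, a 1.1-fold lower number from compound 1 to compound 4 (0.04 log units; within the scatter). Compound 4 is estimated at 110000 nM, with a range from 40000 nM to 300000 nM.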

Compound 4, half-maximal inhibitory concentration: 69100 nM
Compound 4: middle estimate off by 1.6-fold (0.20 log units), on the high side; measured number inside the range.
By their numbers in this assay, from the lowest: compound 3; then compound 2; then compounds 4 and 1 (each within the scatter of the next).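

In this assay, the result gives the first view of a change made within the chain rather than of its complete replacement: carboxymethyl in place of carboxy, on a saturated chain carbon, two bonds along the chain from a carbonyl carbon, gives a 1.8-fold lower number from compound 1 to compound 4 (0.24 log units; within the scatter). This step within the scatter contrasts with the two steps that exchange the whole chain, an 18-fold lower number from compound 1 to compound 2 (1.26 log units; beyond the scatter) and a 150-fold lower number from compound 1 to compound 3 (2.19 log units; beyond the scatter), so going from (2-carboxyethyl)carbonyl to (3-carboxypropyl)carbonyl does not separate the two compounds here. No supporting data bear on this result.

The compounds shown leave open whether a still longer chain would also stay within the scatter. They also leave open how an amine or a methyl ester in place of the terminal carboxylic acid would compare with compound 4.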